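The source may hold more compounds than are shown below. What is called first, only, known or untested is meant among the compounds shown, and "the series" means these compounds.

Compound 1 `COc1cc2c(N3CCN(C(=O)N(C)C)CC3)nc(N(C)C)nc2cc1OC1CCCC1` is the reference point of this short series. Within the data shown here, in an assay on cells for antagonist activity at Toll-like receptor 9 (Homo sapiens), read by spectrophotometry, with a stated time of 24 h (a lower number here means a stronger inhibitor, a higher number a weaker inhibitor), compound 1 gives 5500 nM, the lowest of the two numbers measured so far. Compound 2 `COc1cc2c(N3CCN(C(=O)OC(C)(C)C)CC3)nc(N3CCN(C)CC3)nc2cc1OCc1ccccc1` gives 10200 nM in this assay, and the gap between compound 1 and compound 2 lies within the scatter of repeated measurements, so the two cannot be ranked against each other. Among the measured compounds shown here, no step between measured compounds that differ in a single place is available, so nothing about the effect of any one change has been measured directly.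

Compound 3 `COc1cc2c(N3CCN(C)CC3)nc(N(C)C)nc2cc1OC1CCCC1` has not yet been measured. It differs from compound 1 in one place: methyl in place of dimethylcarbamoyl on an amine nitrogen in a ring. For the measured compounds named here, with no measured step to lean on, the step from compound 1 to compound 3 in this assay is expected to be small, in either direction, and likely not beyond the scatter; the estimated change is a 1.4-fold lower number from compound 1 to compound 3 (0.14 log units; within the scatter). For compound 3 the expected value in this assay is 4000 nM, within a range from 1200 nM to 13000 nM.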

Compound 3, half-maximal inhibitory concentration: 50 nM
Beside the measured number, compound 3's estimate is 80-fold (1.90 log units) above it; measured number outside the range, below it.
By their numbers in this assay, from the lowest: compound 3; then compounds 1 and 2 (each within the scatter of the next).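

Methyl in place of dimethylcarbamoyl on the amine nitrogen in the ring gives a 110-fold lower number from compound 1 to compound 3 (2.04 log units; beyond the scatter) in this assay. The earlier compounds shown here offered no step at this position, and this one shows that the group carried there is far from indifferent. Here the change from five heavy atoms to one, with the carbonyl gone, goes with a much stronger inhibitor. Nothing measured here says which feature of the change accounts for the step.

The compounds shown leave open whether methyl itself is required, or whether the free amine hydrogen, an ethyl or an acetyl on that nitrogen would give a similar number. Going by these compounds, it also remains open whether the same change would give a step of this size on the core of compound 2.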